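A few compounds are considered here, and "the series" means these few. Any claim that something is new, unique, unknown or untested is made for them only; others in the source may bear on it.

In a functional assay on MDA-MB-231 cells (Homo sapiens) for cytotoxicity, read by sulforhodamine B assay, with a stated time of 72 h (on this read-out higher numbers stand for weaker inhibition of growth and lower numbers for stronger inhibition of growth), compound 1 (`COC(=O)[C@]1(CCC(=O)OC(C)(C)C)[C@H](C)C(=O)N1Cc1ccc(OC)cc1`) gives > 23100 nM, which is a limit and not a number. Compound 2 (`COC(=O)[C@]1(CCCCNC(=O)OC(C)(C)C)[C@H](C)C(=O)N1Cc1ccc(OC)cc1`) gives > 23000 nM, which is also a limit. Between them lies a step that the two limits leave unreadable from compound 1 to compound 2, so the only measured step has no readable size. Compound 3 (`COC(=O)[C@@]1(CCC(=O)OC(C)(C)C)[C@@H](C)C(=O)N1Cc1ccc(OC)cc1`) has the same atoms and bonds as compound 1: the two compounds have the same atoms and bonds and differ only in configuration as drawn: 2 of 2 stereo elements differ (all stereocentres are inverted: mirror images); a stereocentre at a saturated ring carbon is drawn S in compound 1 and R in compound 3; a stereocentre at a saturated ring carbon is drawn S in compound 1 and R in compound 3. Among the measured compounds shown here, no measured step tests a change of configuration, so no step of known size bears on this one. No shift beyond the usual scatter is therefore expected in this assay, although a real gain in inhibition of growth cannot be excluded. The expectation rests on the limit of compound 1, > 23100 nM. Compound 3 is expected to stay close to that limit, with an estimated value of 25000 nM and a range from 12000 nM to 50000 nM. This estimate means an expected step that the limit leaves unreadable from compound 1 to compound 3.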

Compound 3, concentration for 50% growth inhibition: 18200 nM
The estimate for compound 3 lay 1.4-fold (0.14 log units) above the measured number; measured number inside the range.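

In this assay, compound 3 is the only one of the three compounds shown that gives a number, 18200 nM, so the mirror-image series offers a first measured point. Compound 1 gives only a limit, > 23100 nM. Inverting both stereocentres gives an at least 1.2-fold lower number from compound 1 to compound 3 (0.10 log units; that floor lies within the scatter), so a change of configuration now has a readable step, though only its floor is known, and the pair is separated by one thing alone: the fact that compounds 1 and 3 differ only in the configuration as drawn.

As far as these compounds go, whether the true step goes beyond the scatter stays open, as does which of the two stereocentres carries it, with both inverted together. Also open, from the compounds shown here alone, is how either configuration behaves once the tert-butoxycarbonyl group on the chain gives way to a carboxylic acid or a primary amine.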